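The compounds below may be only part of what the source reports. "The series", "measured", "known", "first", "only" and "open" are said of these compounds alone.

Measured so far in an assay on mitochondria from L6 cells (Rattus norvegicus) for activation, with a stated time of 90 min; on this read-out lower numbers stand for an effect already at smaller amounts and higher numbers for an effect only at larger amounts of compound:
compound 1 `FC(F)(F)Oc1cccc(Nc2nc3nonc3nc2Nc2cccc(OC(F)(F)F)c2)c1` gives 1100 nM
compound 2 `FC(F)(F)Oc1ccc(Nc2nc3nonc3nc2Nc2ccc(OC(F)(F)F)c(Br)c2)cc1Br` gives 2200 nM
compound 3 `Fc1ccccc1Nc1nc2nonc2nc1Nc1ccccc1` gives 2200 nM

All three share one core with two aryl amine arms and differ only in what sits on those arms. Compound 3 stands level with compound 2 at the digits shown, and the number for compound 1 lies within the scatter of the value for compound 3, so the three measured compounds are not separated by this assay beyond its usual noise.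

Compound 4 `CCOc1cccc(Nc2nc3nonc3nc2Nc2ccccc2F)c1` is not yet measured. It differs from compound 3 by ethoxy in place of hydrogen on an aromatic carbon. The new ethoxy sits on the ring that carries no fluorine, meta to a large group, and it is a small, neutral, acceptor-only substituent.

Among the compounds with values here, no measured pair in this assay shows the same change, so the step from compound 3 has no direct precedent here. The three numbers on hand, all within scatter of each other, give no ground to expect a large shift in either direction. The estimate is therefore a step that stays within or at the edge of the scatter, leaning slightly toward a lower number, a 1.5-fold lower number from compound 3 to compound 4 (0.17 log units; within the scatter).

Compound 4 is expected at about 1500 nM in this assay, with a range from 500 nM to 5000 nM.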

Compound 4, half-maximal effective concentration: 2200 nM
Estimate against measurement, compound 4: 1.5-fold (0.17 log units) below; measured number inside the range.
By their numbers in this assay, from the lowest: compounds 1, 2, 3 and 4 (each within the scatter of the next).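

In this assay, within the data shown here, the step of no change at the digits printed from compound 3 to compound 4 (within the scatter) comes with ethoxy in place of hydrogen on an aromatic carbon, meta to a large group, and it is the first comparison between compounds that differ in one place. The earlier compounds shown here differed in more than one place, so they could not show what a single substituent does on this arm; here the read-out holds when ethoxy enters on the ring that carries no fluorine, so this position tolerates this group without a shift beyond the usual scatter. Nothing at hand accounts for this result.

One substituent at one position does not settle whether the read-out stays level for other groups there, and an amine, a carboxylic acid or a longer chain in place of ethoxy could still move it in either direction. From the compounds shown here alone, it also remains open whether ethoxy would read the same at another place on this ring or on the ring that carries the fluorine.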